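The compounds below may be only part of what the source reports. "The series", "measured", "known", "first", "only" and "open" are said of these compounds alone.

Measured compounds:
compound 1, `CCCSC1=N[C@H](C(=O)OC)[C@@H]2C(=O)N(c3ccccc3)C(=O)[C@H]12`: 86%
compound 2, `CCCSC1=N[C@@H](C(=O)OC)[C@@H]2C(=O)N(c3ccccc3)C(=O)[C@H]12`: 86%

In a functional assay for inhibition, tested at 100 uM (a lower number here means less inhibition, a higher number more inhibition at the concentration tested (going by the name of the read-out)), compound 2 gives 86%, level with compound 1. Within the data shown here, the only measured step, no change at the digits printed from compound 1 to compound 2 (within the scatter), turns on (the fact that compounds 1 and 2 differ only in the configuration as drawn), a change of configuration alone.

Compound 3, `COC(=O)[C@@H]1N=C(SC)[C@H]2C(=O)N(c3ccccc3)C(=O)[C@H]21`, differs from compound 2 by hydrogen in place of ethyl on a saturated chain carbon bound to a sulfur. Among the measured compounds shown here, no measured step concerns a shortening of the chain on sulfur, so the configuration step offers no guide to the size of this change. The step is expected to be a number 8 percentage points lower from compound 2 to compound 3 (within the scatter), a modest fall at most. Compound 3 is estimated at 78%, with 50% as the lower end and 95% as the upper end.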

Compound 3, a percentage reported as inhibition, at one concentration (the size of the read-out at that concentration, not a potency): 93%
Compound 3: the middle estimate sits 15 percentage points below what was measured, and the stated range covers the measured number.
By their numbers in this assay, from the lowest: compounds 1, 2 and 3 (each within the scatter of the next).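

In this assay, replacing propylsulfanyl with methylsulfanyl gives a number 7 percentage points higher from compound 2 to compound 3 (within the scatter). Among these compounds, this is the first view of the group on sulfur, whose chain can be shortened from propyl to methyl with no shift beyond the scatter, so the read-out at this concentration does not depend on the propyl chain. Nothing shown here accounts for this result.

From the compounds shown here alone, whether a longer chain such as hexyl, or a benzyl group or an amine carried on the sulfur, would keep this level of inhibition stays open. So does the outcome of replacing the methyl ester with a carboxylic acid.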